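Sulfonamide naphthoquinones: swapping a methoxy for an ethoxycarbonyl

A few compounds are considered here, and "the series" means these few. Any claim that something is new, unique, unknown or untested is made for them only; others in the source may bear on it.

Measured compounds:
compound 1 `COc1ccc(S(=O)(=O)NC(C)C2=CC(=O)c3c(O)ccc(O)c3C2=O)cc1`: 3760 nM
compound 2 `COc1ccc(S(=O)(=O)NC(C)C2=CC(=O)c3c(O)ccc(O)c3C2=O)c(OC)c1`: 19500 nM

In a functional assay on HeLa cells (Homo sapiens) for cytotoxicity, read by sulforhodamine B assay (on this read-out higher numbers stand for weaker inhibition and lower numbers for stronger inhibition), compound 1 gives 3760 nM, the lowest of the two numbers measured; compound 2 gives 19500 nM. Among the compounds with values here, the only measured step is a 5.2-fold higher number from compound 1 to compound 2 (0.71 log units; beyond the scatter), which accompanies a methoxy in place of hydrogen on an aromatic carbon.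

Compound 3 `CCOC(=O)c1ccc(S(=O)(=O)NC(C)C2=CC(=O)c3c(O)ccc(O)c3C2=O)cc1` is not yet measured. It differs from compound 1 by ethoxycarbonyl in place of methoxy on an aromatic carbon. Within the data shown here, no measured step concerns an ethoxycarbonyl, and the one known step changed a different position, so it bears only loosely on this change. A step of unclear direction is expected, most likely no larger than the scatter. Compound 3 is estimated at 5000 nM, with a range from 1500 nM to 16000 nM, which would mean an expected step of a 1.3-fold higher number from compound 1 to compound 3 (0.12 log units; within the scatter).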

Compound 3, half-maximal inhibitory concentration: 2260 nM
Compound 3: middle estimate off by 2.2-fold (0.34 log units), on the high side, within the range that was stated.
By their numbers in this assay, from the lowest: compounds 3 and 1 (each within the scatter of the next); then compound 2.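

In this assay, replacing methoxy with the larger ethoxycarbonyl, on the aromatic carbon para to a large group, gives a 1.7-fold lower number from compound 1 to compound 3 (0.22 log units; within the scatter). Within the data shown here, this position therefore accepts a group with more heavy atoms and a double bond outside the aromatic ring, with no shift that stands clear of the usual scatter, unlike the one earlier step, a 5.2-fold higher number from compound 1 to compound 2 (0.71 log units; beyond the scatter), which added a methoxy elsewhere on the ring. No measurement shown explains why these two changes differ in their outcome.

Going by these compounds, it remains open whether a carboxylic acid, an amine or a longer alkyl chain on this same carbon would also stay within the scatter of compound 1. On these data alone, it is also open how ethoxycarbonyl would fare alongside the extra methoxy of compound 2.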